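Three compounds at the limit, and a fourth in waiting

The compounds below may be only part of what the source reports. "The series", "measured", "known", "first", "only" and "open" are said of these compounds alone.

Three compounds sharing one core were measured in an in vitro assay on U2OS cells for agonist activity at neurotensin receptor type 2 (Homo sapiens), read by reporter gene assay and beta-arrestin recruitment; a lower number here means that less compound is needed, a higher number that more compound is needed for the effect. Compound 1 `COc1cc2nc(C3CCC3)nc(N3CCN(c4ccccc4F)CC3)c2cc1OC` gives > 80000 nM, which is a limit of the assay and not a number. Compound 2 `COc1cc2nc(C3CCC3)nc(N3CCN(c4ccccn4)CC3)c2cc1OC` gives > 80000 nM, again a limit. The step that the two limits leave unreadable from compound 1 to compound 2 therefore cannot be read. Compound 3 `CCc1nc(N2CCN(c3ccccc3OC)CC2)c2cc(OC)c(OC)cc2n1` gives > 80000 nM, likewise a limit. Compound 3 thus stands where every measured compound here stands, at the edge of what the assay reports: the limit of > 80000 nM in this assay, at which 3 of the 3 values shown sit.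

Compound 4 `COc1cc2nc(CC(C)C)nc(N3CCN(c4ccccc4OC)CC3)c2cc1OC` has not yet been measured. It differs from compound 3 by isopropyl in place of methyl on a saturated chain carbon bound to an aromatic carbon. For the measured compounds named here, none of the measured steps touches this part of the structure, and the one measured step, a step that the two limits leave unreadable from compound 1 to compound 2, changes the group on the amine nitrogen in a ring and is itself unreadable. Going by the values given here, what carries over is only that all three measured compounds sit at the limit. Among the compounds with values here, the account therefore expects compound 4 to remain there as well, with no step in this assay readable beyond the scatter. The estimated step is a number no higher from compound 3 to compound 4 (the limit leaves the size open). For compound 4 the expected value is 80000 nM, within 20000 nM to 200000 nM.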

Compound 4, half-maximal effective concentration: > 80000 nM
Compound 4 ended at the assay's limit; the forecaster's own chance of this, stated with the estimate: 80%; the middle value sits exactly at the limit.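

Compound 4, like compound 3, ends at a limit of this assay and not at a number, and no new step can be read from this result. All the compounds shown now stand together: the limit of > 80000 nM in this assay, at which 4 of the 4 values shown sit.

What they leave open is whether any change to the shared core gives a value that this assay can report as a number.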